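The source may report more compounds than this note shows. Statements on the series, on what has been measured and on what is new or still open speak of the compounds shown alone.

Of the compounds shown here, three built on one shared core have been tested in a functional assay on the whole organism (strain Wistar albino) for inhibition, with Rattus norvegicus as the target, read by paw edema, with stated times of 1 h and 4 h, at a dose of 40 mg/kg by the oral route; on this read-out lower numbers stand for less inhibition and higher numbers for more inhibition at the one dose given (going by the name of the read-out). Compound 1 `Cc1nc(Cc2ccc(Cl)cc2)sc1C1SCC(=O)N1c1ccc(F)c(Cl)c1` carries a 3-chloro-4-fluorophenyl group on the amide-type nitrogen of the ring, and in this assay compound 1 gives 68.9%. Compound 2 `Cc1ccc(N2C(=O)CSC2c2sc(Cc3ccc(Cl)cc3)nc2C)cc1` carries a 4-methylphenyl group in that place instead, and compound 2 gives 81.3%. Among the compounds with values here, that exchange is the one measured step, a number 12.4 percentage points higher from compound 1 to compound 2 (beyond the scatter), which shows that the group on this nitrogen can move the read-out by a modest but real amount.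

Compound 3 `Cc1nc(Cc2ccc(Cl)cc2)sc1C1SCC(=O)N1c1ccccc1` carries a plain phenyl group in the same place. For compound 3 the result is "not active" (no number reported), so no single number exists for it; it stands apart from compound 1 and compound 2, both of which show clear inhibition.

Compound 4 `Cc1nc(Cc2ccc(Cl)cc2)sc1C1SCC(=O)N1c1ccc(Cl)cc1` differs from compound 3 by chloro in place of hydrogen on an aromatic carbon. Within the data shown here, no measured step covers this exact change, but compound 1 and compound 2, each bearing a substituted phenyl, give numbers in this assay, while compound 3, with the unsubstituted phenyl, is reported as not active, so a substituted ring may be expected to give a higher number in this assay, though with considerable uncertainty. Compound 4 is therefore estimated to give 55%, with a range from 25% to 80%.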

Compound 4, a percentage reported as inhibition, in the whole organism at one dose (the size of the read-out at that dose, not a potency): 53.9%
Beside the measured number, compound 4's estimate is 1.1 percentage points above it; the range from low to high includes it.
By their numbers in this assay, from the lowest: compound 4; then compound 1; then compound 2.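

Compound 3 gives "not active" (no number reported) in this assay, while compound 4, with phenyl changed to 4-chlorophenyl, gives 53.9%, so a single chloro on this ring is enough to turn a compound without a reported number into one with a measurable effect, although no numerical step can be read for this pair. The identity of the added group also matters, since chloro in place of methyl at the same place gives a number 27.4 percentage points lower from compound 2 to compound 4 (beyond the scatter), showing that a substituent here does not simply give the same result whichever group it is. The halogen pattern matters too, since 4-chlorophenyl in place of 3-chloro-4-fluorophenyl gives a number 15 percentage points lower from compound 1 to compound 4 (beyond the scatter), which separates two rings that both carry halogens.

Nothing available here gives a reason for these differences. Still open, going by these compounds, is how the read-out would respond to other groups at this place on the ring, such as methoxy, an amine or a carboxylic acid, and whether a lone fluoro or a longer chain such as ethyl in place of the chloro would keep the effect.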